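The source may hold more compounds than are shown below. What is called first, only, known or untested is meant among the compounds shown, and "the series" means these compounds.

Among the three compounds measured in a functional assay on MCF7 cells (Homo sapiens) for antiproliferative activity, read by sulforhodamine B assay, with a stated time of 72 h (a lower number here means a stronger inhibitor, a higher number a weaker inhibitor), compound 2 `COc1ncc(-c2ccc3ncnc(Nc4ccc(OCCO)c(Cl)c4)c3c2)cc1NS(=O)(=O)c1ccc(F)cc1F` stands highest with 3740 nM. Compound 3 `COc1ncc(-c2ccc3ncnc(Nc4ccc(OCCO)nc4)c3c2)cc1NS(C)(=O)=O` gives 3080 nM, within the scatter of compound 2, while compound 1 `COc1ncc(-c2ccc3ncnc(Nc4cnn(CCCO)c4)c3c2)cc1NS(C)(=O)=O` gives 730 nM, beyond the scatter below it. The unmeasured compound 4 `COc1ncc(-c2ccc3ncnc(Nc4cnn(CCCO)c4)c3c2)cc1NS(=O)(=O)c1ccc(F)cc1F` differs from compound 2 by 1-(3-hydroxypropyl)-1H-pyrazol-4-yl in place of 3-chloro-4-(2-hydroxyethoxy)phenyl on a nitrogen on an aromatic ring. Among the compounds with values here, one measured step bears on this change: a 4.2-fold higher number from compound 1 to compound 3 (0.63 log units; beyond the scatter), which runs the opposite way, the 1-(3-hydroxypropyl)-1H-pyrazol-4-yl compound giving the lower number. Since the same group enters here, compound 4 is expected to give a lower number than its parent, by about a 3.1-fold lower number from compound 2 to compound 4 (0.49 log units; beyond the scatter). For compound 4 the estimate in this assay is 1200 nM, with a range from 400 nM to 3600 nM.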

Compound 4, half-maximal inhibitory concentration: 1310 nM
Estimate against measurement, compound 4: 1.1-fold (0.04 log units) below; the range from low to high includes it.
By their numbers in this assay, from the lowest: compounds 1 and 4 (each within the scatter of the next); then compounds 3 and 2 (each within the scatter of the next).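

In this assay the exchange on the nitrogen on an aromatic ring now also holds with 2,4-difluorophenyl on the sulfonyl sulfur, with a 2.9-fold lower number from compound 2 to compound 4 (0.46 log units; beyond the scatter) in the same direction as the earlier step. With 1-(3-hydroxypropyl)-1H-pyrazol-4-yl in place, the sulfonyl exchange gives a 1.8-fold higher number from compound 1 to compound 4 (0.25 log units; within the scatter) and so shows no clear change. No evidence is available to explain either step.

As far as these compounds go, whether the sulfonyl exchange behaves alike with other groups on that nitrogen remains open. So does the effect of an amine or a carboxylic acid replacing the hydroxyl at the end of the 3-hydroxypropyl chain.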